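Swapping one side group in an antiproliferative series

The source may hold more compounds than are shown below. What is called first, only, known or untested is meant among the compounds shown, and "the series" means these compounds.

Compound 1 `COC/C1=C/C[C@](C)(CCC=C(C)C)/C=C/[C@@H](OC(=O)C=C(C)C)[C@](C)(O)/C=C/C1=O`: 3850 nM
Compound 2 `CC[Si](CC)(CC)C/C1=C/C[C@](C)(CCC=C(C)C)/C=C/[C@@H](OC(=O)C=C(C)C)[C@](C)(O)/C=C/C1=O`: 2690 nM
Compound 3 `CO/N=C/C1=C/C[C@](C)(CCC=C(C)C)/C=C/[C@@H](OC(=O)C=C(C)C)[C@](C)(O)/C=C/C1=O`: not yet measured

In a functional assay on SW480 cells (Homo sapiens) for antiproliferative activity, read by MTT assay, with a stated time of 48 h (on this read-out higher numbers stand for weaker inhibition and lower numbers for stronger inhibition), compound 2 stands level with compound 1: a 1.4-fold lower number from compound 1 to compound 2 (0.16 log units; within the scatter). Compound 3 differs from compound 2 by a group of 4 heavy atoms (2 carbon, 1 nitrogen, 1 oxygen; no ring) in place of a group of 8 heavy atoms (7 carbon, 1 silicon; no ring), on a double-bonded ring carbon. That single measured step bears on this change only loosely, since it exchanged different groups, and it stayed within the scatter. No shift beyond the scatter is therefore expected in this assay. The expected step is a 1.1-fold higher number from compound 2 to compound 3 (0.05 log units; within the scatter). For compound 3 the estimated value is 3000 nM, ranging from 1200 nM to 8000 nM.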

Compound 3, half-maximal inhibitory concentration: 2630 nM
Estimate against measurement, compound 3: 1.1-fold (0.06 log units) above; the range from low to high includes it.
By their numbers in this assay, from the lowest: compounds 3, 2 and 1 (each within the scatter of the next).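

In this assay, the change on the double-bonded ring carbon gives a 1.0-fold lower number from compound 2 to compound 3 (0.01 log units; within the scatter), and the same place gives a 1.5-fold lower number from compound 1 to compound 3 (0.17 log units; within the scatter). The group entering in compound 3, with its double bond outside aromatic rings and its hydrogen-bond acceptors, therefore reads level with both earlier groups, so three different groups at this place have yet to separate beyond the scatter. No measurement shown explains this levelness. From the compounds shown here alone, whether an amine or a carboxylic acid at this place would move the number beyond the scatter remains open. The compounds shown also leave open whether a change elsewhere on the shared core would do so.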